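A few compounds are considered here, and "the series" means these few. Any claim that something is new, unique, unknown or untested is made for them only; others in the source may bear on it.

Measured in a functional assay on K562 cells (Homo sapiens) for antiproliferative activity, read by CCK-8 assay, with a stated time of 72 h; on this read-out lower numbers stand for stronger inhibition of growth and higher numbers for weaker inhibition of growth:
compound 1 `CCC1C(=O)N(C)c2cnc(Nc3ccc(S(=O)(=O)NCC(C)C)cc3)nc2N1c1ccn(C)n1` — compound 1 gives 7300 nM
compound 2 `CCCNS(=O)(=O)c1ccc(Nc2ncc3c(n2)N(c2ccn(C)n2)C(CC)C(=O)N3C)cc1` — compound 2 gives 2260 nM
compound 3 `CCCNC(=O)c1ccc2c(ccn2-c2ncc3c(n2)N(C2CCCC2)[C@H](CC)C(=O)N3C)c1` — compound 3 gives 395 nM

Compound 3 has the lowest number of the three; compound 2 is nearest to it and compound 1 furthest, both beyond the scatter. Compound 2 and compound 3 share no single counted difference; the difference between the two cores is not broken down here. Within the core of compound 2, the step of a 3.2-fold higher number from compound 2 to compound 1 (0.51 log units; beyond the scatter) goes with methyl in place of hydrogen on a saturated chain carbon bound to two saturated chain carbons.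

Compound 4 `CCCCNC(=O)c1ccc2c(ccn2-c2ncc3c(n2)N(C2CCCC2)[C@H](CC)C(=O)N3C)c1` is not yet measured. It differs from compound 3 by methyl in place of hydrogen on a saturated chain carbon, three bonds along the chain from an amide-type nitrogen. This is the same kind of change as that from compound 2 to compound 1, not the same: there the methyl entered on a saturated chain carbon bound to two saturated chain carbons, here it enters three bonds along the chain from an amide-type nitrogen.

In this assay the step of a 1.3-fold higher number from compound 3 to compound 4 (0.12 log units; within the scatter) is expected, smaller than the earlier step because a 3.2-fold higher number from compound 2 to compound 1 (0.51 log units; beyond the scatter) was only modest and was made at a different place on a different core. Compound 4 is estimated at 520 nM, likely between 250 nM and 1200 nM.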

Compound 4, concentration for 50% growth inhibition: 673 nM
Estimate against measurement, compound 4: 1.3-fold (0.11 log units) below; measured number inside the range.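

In this assay the added methyl on the chain gives a 1.7-fold higher number from compound 3 to compound 4 (0.23 log units; within the scatter) and this does not separate from the earlier step on the other core: the same change on two cores in this assay, a 3.2-fold higher number (0.51 log units; beyond the scatter) from compound 2 to compound 1 and a 1.7-fold higher number (0.23 log units; within the scatter) from compound 3 to compound 4, 1.9-fold (0.28 log units) apart, within the scatter of two such steps
The two steps are therefore compatible with a change of this kind having a similar size on both cores, although only the earlier step lies beyond the scatter. This does not establish that the step carries over in general: the comparison rests on just two pairs, the methyl enters at a different place on each chain, and the two cores differ in more than one place.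

Left open is how a pentyl or longer chain, or a terminal amine or carboxylic acid on the butyl chain, would read on the core of compound 3. Also open, as far as these compounds go, is whether a butyl chain in place of the propyl chain on the core of compound 2 would give a step of similar size.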